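The compounds below may be only part of what the source reports. "The series", "measured", "known", "first", "only" and "open" are said of these compounds alone.

Measured in a physicochemical assay for lipophilicity, measured as octanol-water partition; a higher number here means a more lipophilic compound, a lower number a more polar compound:
- compound 1 `CC(C)[C@@H]1CC[C@@H](C)C[C@H]1OC(=O)c1cccc([N+](=O)[O-])c1`: 4.78
- compound 2 `CC(C)[C@@H]1CC[C@@H](C)C[C@H]1OC(=O)c1ccc(Cl)cc1Cl`: 5.86

Compound 1 stands lower of the two, and the gap up to compound 2 lies beyond the usual scatter. Compound 3 `COc1cccc(C(=O)O[C@@H]2C[C@H](C)CC[C@H]2C(C)C)c1` has not yet been measured. It keeps the core of compound 1 and changes one group: methoxy in place of nitro on an aromatic carbon, meta to a large group. Within the data shown here, no measured pair shows this change, and compound 2 offers little guide to it. In this assay a small upward step is expected, a number 0.22 log units higher from compound 1 to compound 3 (within the scatter), which would lie within the scatter. The estimate for compound 3 is 5, with an expected range of 4.6 to 5.4.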

Compound 3, partition coefficient: 4.57
Beside the measured number, compound 3's estimate is 0.43 log units above it; measured number below the stated range.
By their numbers in this assay, from the lowest: compounds 3 and 1 (each within the scatter of the next); then compound 2.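

In this assay, among these compounds, putting methoxy in place of nitro on an aromatic carbon, meta to a large group, gives the first direct pair for this change (a number 0.21 log units lower from compound 1 to compound 3 (within the scatter)). On the core of compound 1, the two groups therefore cannot be told apart at this position in this assay. Nothing available explains this result. From the compounds shown here alone, whether an amine, a carboxylic acid or a longer chain at this position would stand apart from nitro and methoxy remains open. Also open, going by these compounds, is whether the same swap would give a similar step at another place on the aromatic ring.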